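The compounds below may be only part of what the source reports. "The series", "measured", "known", "first", "only" and "open" are said of these compounds alone.

Compound 1 `O=C1O/C(=C\Cn2cc(I)c(=O)[nH]c2=O)C(OCc2ccccc2)=C1OCc1ccccc1`: 10000 nM
Compound 2 `O=C1O/C(=C\Cn2ccc(=O)[nH]c2=O)C(OCc2ccccc2)=C1OCc1ccccc1`: 40000 nM
Compound 3 `O=C1O/C(=C\Cn2cnc3c(-n4cccc4)ncnc32)C(OCc2ccccc2)=C1OCc1ccccc1`: > 100000 nM (a limit)

In a functional assay on HEp-2 cells (Homo sapiens) for inhibition (on this read-out higher numbers stand for weaker inhibition and lower numbers for stronger inhibition), compound 2 stands highest of the two actual numbers at 40000 nM, and compound 1 is nearest at 10000 nM. Going by the values given here, the entry for compound 3 is only a limit, (the limit of > 100000 nM in this assay, at which 1 of the 3 values shown sits), and gives no step.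

Compound 4 `O=C1O/C(=C\Cn2cc(Br)c(=O)[nH]c2=O)C(OCc2ccccc2)=C1OCc1ccccc1` follows from compound 2 by bromo in place of hydrogen on an aromatic carbon. Among the compounds with values here, one measured step bears on this: a 4.0-fold higher number from compound 1 to compound 2 (0.60 log units; beyond the scatter), with hydrogen in place of iodo. Read in reverse, it suggests a modest move to a lower number in this assay, resting on this single pair. The expected step is a 2.7-fold lower number from compound 2 to compound 4 (0.43 log units; beyond the scatter). For compound 4 the estimate is 15000 nM, with an expected range of 5000 nM to 40000 nM.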

Compound 4, half-maximal inhibitory concentration: 90000 nM
The estimate for compound 4 lay 6.0-fold (0.78 log units) below the measured number; measured number above the stated range.
By their numbers in this assay, from the lowest: compound 1; then compound 2; then compound 4. At a limit, above all of these: compound 3.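

In this assay, halogen on this aromatic carbon does not move the number in one direction: iodo stands with the lower number against hydrogen, whereas bromo gives a 2.3-fold higher number from compound 2 to compound 4 (0.35 log units; beyond the scatter). The exchange of iodo for bromo is the largest step in the set, at a 9.0-fold higher number from compound 1 to compound 4 (0.95 log units; beyond the scatter). Compound 3 stands at a limit, so it extends no such comparison: the limit of > 100000 nM in this assay, at which 1 of the 4 values shown sits.

On these data alone, whether chloro, fluoro, methyl or an amine on this carbon would give a lower or a higher number remains open. As far as these compounds go, with one pair for each halogen, it also remains open whether this order holds on any other core.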